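This account rests on a few compounds, and the source may have more. Where it says the series, first, only, none or still open, it means among the compounds named here.

Working notes on the series. In a toxicity assay on the whole organism (J774 cells) for cytotoxicity, with Mus musculus as the target, read by MTT assay, with a stated time of 24 h, tested at 10 uM (a higher number here means a weaker effect of the compound at the concentration tested, a lower number a stronger effect), compound 1 `CCCCCCCCCO[C@@H]1[C@@H](N)[C@@H](OCC(O)CNCCN)O[C@H](CN)[C@H]1OCCCCCCCCC` gives 87.5%; compound 2 `CCCCCCCCCO[C@@H]1[C@@H](N)[C@@H](OCC(O)CNCCO)O[C@H](CN)[C@H]1OCCCCCCCCC` gives 99.1%; compound 3 `CCCCCCCCCO[C@@H]1[C@@H](N)[C@@H](OCC(O)CO)O[C@H](CN)[C@H]1OCCCCCCCCC` gives 89.7%. Compound 3 sits within the scatter of both others, as a number 2.2 percentage points higher from compound 1 to compound 3 (within the scatter) and a number 9.4 percentage points lower from compound 2 to compound 3 (within the scatter) show. Compound 4 `CCCCCCCCCO[C@@H]1[C@@H](N)[C@@H](OC[C@H](O)CN)O[C@H](CN)[C@H]1OCCCCCCCCC` is not yet measured in this assay. The change is 2-amino-1-hydroxyethyl in place of 1,2-dihydroxyethyl on a saturated chain carbon bound to an oxygen on a saturated carbon. For the measured compounds named here, the only step beyond the scatter so far is a number 11.6 percentage points higher from compound 1 to compound 2 (beyond the scatter), where hydroxy replaced amino; the present change runs the other way, amino entering where hydroxy leaves, so a downward move of similar size is the likeliest outcome, though it could also stay within the scatter. The expected step is a number 7.7 percentage points lower from compound 3 to compound 4 (within the scatter). Compound 4 is estimated at 82%, with a range from 68% to 96%.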

Compound 4, a percentage reported as activity, at one concentration (the size of the read-out at that concentration, not a potency): 88%
Estimate against measurement, compound 4: 6 percentage points below, and the stated range covers the measured number.
By their numbers in this assay, from the lowest: compounds 1, 4, 3 and 2 (each within the scatter of the next, the first and the last beyond it).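

In this assay, the exchange of 1,2-dihydroxyethyl for 2-amino-1-hydroxyethyl gives a number 1.7 percentage points lower from compound 3 to compound 4 (within the scatter), so an amine at this place does not by itself bring a step beyond the scatter. Loss of the 2-aminoethyl end gives a number 0.5 percentage points higher from compound 1 to compound 4 (within the scatter), while loss of the 2-hydroxyethyl end gives a number 11.1 percentage points lower from compound 2 to compound 4 (beyond the scatter), so both steps beyond the scatter among these compounds involve compound 2. No measured evidence bearing on these steps is available.

From the compounds shown here alone, whether a carboxylic acid or a guanidine in place of the terminal amine would move the read-out remains open. So does the effect of a longer chain between the hydroxy-bearing carbon and the amine.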